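The source may report more compounds than this note shows. Statements on the series, on what has been measured and on what is new or still open speak of the compounds shown alone.

Of the compounds shown here, three with one shared core have been measured. Compound 1 `c1ccc(-c2cn3ccnc3c(-c3ccc4ncn(C5CCCCC5)c4c3)n2)cc1` gives 16.5% in a functional assay on SK-MEL-2 cells (Homo sapiens) for inhibition, read by sulforhodamine B assay, with a stated time of 48 h, tested at 10 uM; on this read-out higher numbers stand for more inhibition at the one concentration tested (going by the name of the read-out) and lower numbers for less inhibition. Compound 2 `O=Cc1ccc(-c2cn3ccnc3c(-c3ccc4ncn(C5CCCCC5)c4c3)n2)cc1` gives 27.8% in this assay, a move of a number 11.3 percentage points higher from compound 1 to compound 2 (beyond the scatter). Compound 3 `Fc1ccc(-c2cn3ccnc3c(-c3ccc4ncn(C5CCCCC5)c4c3)n2)cc1` gives 9.82% in this assay, the lowest of the three numbers, after a number 6.7 percentage points lower from compound 1 to compound 3 (within the scatter) and a number 18 percentage points lower from compound 2 to compound 3 (beyond the scatter). Compound 4 `CC(=O)c1ccc(-c2cn3ccnc3c(-c3ccc4ncn(C5CCCCC5)c4c3)n2)cc1` is not yet measured and differs from compound 3 by acetyl in place of fluoro on an aromatic carbon. The step most relevant to this change runs from formyl to fluoro, a number 18 percentage points lower from compound 2 to compound 3 (beyond the scatter), since acetyl and formyl both carry a carbonyl; read in reverse, a modest rise is expected. Compound 4 is therefore estimated at 26%, within 13% to 40%. The expected step is a number 16.2 percentage points higher from compound 3 to compound 4 (beyond the scatter).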

Compound 4, a percentage reported as inhibition, at one concentration (the size of the read-out at that concentration, not a potency): 0.58%
For compound 4 the middle estimate is 25.4 percentage points above the measured one; measured number outside the range, below it.
By their numbers in this assay, from the lowest: compounds 4, 3 and 1 (each within the scatter of the next, the first and the last beyond it); then compound 2.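

At this position, para to a large group, the formyl result does not carry over to acetyl in this assay: methyl in place of hydrogen on the carbonyl carbon gives a number 27.2 percentage points lower from compound 2 to compound 4 (beyond the scatter). Acetyl in place of hydrogen gives a number 15.9 percentage points lower from compound 1 to compound 4 (beyond the scatter), opposite in direction to formyl in place of hydrogen, while acetyl in place of fluoro gives a number 9.2 percentage points lower from compound 3 to compound 4 (within the scatter), so these two groups cannot be told apart here. Nothing available explains the effect of this added methyl.

On these data alone, whether an amine, a carboxylic acid or a longer chain on the carbonyl at this position would match the number of compound 2 remains open.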